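Swapping a Branched Amide Side Chain for an Oxetane

The compounds below may be only part of what the source reports. "The series", "measured", "known", "first", "only" and "open" are said of these compounds alone.

Three measured compounds share a core, and each carries a small side chain on an amide. Compound 1 `C[C@@H](NC(=O)c1ccc(C#Cc2cccc(F)n2)cn1)C(C)(C)O`, compound 2 `C[C@@H](NC(=O)c1ncc(C#Cc2cccc(F)c2)cn1)C(C)(C)O` and compound 3 `C[C@@H](NC(=O)c1ccc(C#Cc2cccc(F)c2)cn1)C(C)(C)C` were all tested in a functional assay on HEK293 cells for positive allosteric modulation of metabotropic glutamate receptor 5 (Rattus norvegicus), read by fluorescence and calcium flux; on this read-out lower numbers stand for smaller maximal responses and higher numbers for larger maximal responses. In this assay compound 1 reaches 63%, compound 2 reaches 64.1%, and compound 3 reaches 66%. Compound 3 stands highest of the three numbers, yet its distance to compound 2 and to compound 1 lies within the scatter, so the three results cannot be told apart.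

Compound 4 `CC1(CCNC(=O)c2ccc(C#Cc3cccc(F)c3)cn2)COC1` has not yet been measured. It differs from compound 3 only in the side chain on the amide-type nitrogen: 2-(3-methyloxetan-3-yl)ethyl in place of 1,2,2-trimethylpropyl on an amide-type nitrogen. Among the compounds with values here, no measured pair shows what such an exchange does to the maximal response; the three measured compounds, each with its own side chain and core, all reach nearly the same number. The step of a number 4 percentage points lower from compound 3 to compound 4 (within the scatter) in this assay is therefore expected to be none beyond the scatter, in either direction. Compound 4 is accordingly estimated to reach 62%, with a range from 45% to 80%.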

Compound 4, largest response reached (reported as efficacy), in percent of the reference or control that the assay uses: 65.7%
Estimate against measurement, compound 4: 3.7 percentage points below, and the stated range covers the measured number.
By their numbers in this assay, from the lowest: compounds 1, 2, 4 and 3 (each within the scatter of the next).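

In this assay, putting 2-(3-methyloxetan-3-yl)ethyl in place of 1,2,2-trimethylpropyl on the amide-type nitrogen gives a number 0.3 percentage points lower from compound 3 to compound 4 (within the scatter) and so provides the only direct comparison shown at this position. The maximal response does not separate the two side chains, even though the entering one carries a four-membered non-aromatic ring with an oxygen and a hydrogen-bond acceptor and lacks the defined stereocentre of the leaving one, so this position accepts at least this one exchange on the shared core without a readable change in the response. Nothing available explains this result.

Going by these compounds, whether a side chain ending in an amine or a carboxylic acid, or a longer chain, would hold the response at this position remains open, as does whether the same exchange would behave alike on the cores of compound 1 and compound 2. The largest response reached also does not tell how much of either compound is needed to reach it, so the two side chains could still differ in that respect.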